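The source may report more compounds than this note shows. Statements on the series, on what has been measured and on what is new or still open speak of the compounds shown alone.

In an assay on isolated protein for inhibition of biotin--protein ligase (Homo sapiens), read by scintillation counting, with a stated time of 10 min (a lower number here means a stronger inhibitor, a higher number a weaker inhibitor), compound 2 `Nc1ccccc1Cn1cc(CCCCC[C@@H]2SC[C@@H]3NC(=O)N[C@@H]32)nn1` gives > 16000 nM, which is a limit of the assay rather than a number. The two other measured compounds share its core and differ only in the group attached to the saturated chain carbon bound to an aromatic nitrogen. Compound 1 `COc1cccc(Cn2cc(CCCCC[C@@H]3SC[C@@H]4NC(=O)N[C@@H]43)nn2)c1` gives > 16000 nM in this assay, again a limit. Compound 3 `O=C1N[C@H]2[C@H](CS[C@H]2CCCCCc2cn(Cc3ccc(I)cc3)nn2)N1` gives > 16000 nM in this assay, also a limit. All three values sit at the limit of > 16000 nM in this assay, at which 3 of the 3 values shown sit, so the steps between them cannot be read: a step that the two limits leave unreadable from compound 1 to compound 2, a step that the two limits leave unreadable from compound 1 to compound 3 and a step that the two limits leave unreadable from compound 2 to compound 3 all stay hidden. Compound 4 `O=C1N[C@H]2[C@H](CS[C@H]2CCCCCc2cn(Cc3ccccc3Cl)nn2)N1` is the next one to be measured in this assay. It differs from compound 2 in one place: chloro in place of amino on an aromatic carbon. Going by the values given here, none of the measured steps has a readable size, so there is no step of the same kind to lean on; what is known is only that three different groups at this place all left the compounds too weak to register. On that footing compound 4 is expected to behave like them, with an estimated step that the limit leaves unreadable from compound 2 to compound 4 that means no reading past the limit. The estimate for compound 4 is therefore 20000 nM, expected to lie between 6000 nM and 60000 nM, and the assay will most likely again report only a limit.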

Compound 4, inhibition constant: > 16000 nM
Compound 4: only a limit was reported; the forecaster's own chance of this, stated with the estimate: 85%; the middle value is on the limit's open side.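

In this assay compound 4 gives > 16000 nM, which is a limit of the assay and not a number. No step between compound 1, compound 2, compound 3 and compound 4 can be read, since all four stop at the same point: the limit of > 16000 nM in this assay, at which 4 of the 4 values shown sit.

The compounds shown leave open how weak each one really is, and whether any group at this place could give a measurable value.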